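A few compounds are considered here, and "the series" means these few. Any claim that something is new, unique, unknown or untested is made for them only; others in the source may bear on it.

In a functional assay on thoracic aorta (Rattus norvegicus, strain Wistar), with a stated time of 15 min (a higher number here means that more compound is needed for the effect, a lower number that less compound is needed), compound 1 `COc1ccc(Br)cc1C(C)NC(=O)NS(=O)(=O)c1ccc(C)cc1` gives > 300000 nM, which is a limit of the assay and not a number. Among the compounds with values here, compound 2 `Cc1ccc(S(=O)(=O)NC(=O)NC(C)c2cc(Br)ccc2OCc2ccccc2)cc1` gives 138000 nM, the only actual number so far in this assay. Compound 3 `CCOc1ccc(Br)cc1C(C)NC(=O)NS(=O)(=O)c1ccc(C)cc1` differs from compound 2 by methyl in place of phenyl on a saturated chain carbon bound to an oxygen on an aromatic ring, or benzyloxy to ethoxy. Within the data shown here, one measured step bears on this change, at the same carbon. It is an at least 2.1-fold lower number from compound 1 to compound 2 (0.33 log units; beyond the scatter), with phenyl in place of hydrogen. Because an at least 2.1-fold lower number from compound 1 to compound 2 (0.33 log units; beyond the scatter) accompanied the arrival of the phenyl, its loss is expected to give back part or all of that modest gain. Among the measured compounds shown here, a higher number is therefore expected in this assay, perhaps close to the limit seen for compound 1, and no measured step shows how much of the gain returns. The expected step is a 1.8-fold higher number from compound 2 to compound 3 (0.26 log units; within the scatter). For compound 3 the estimated value is 250000 nM, with an expected range from 120000 nM to 450000 nM.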

Compound 3, half-maximal effective concentration: > 300000 nM
Compound 3: a limit, no number; the forecaster's own chance of this, stated with the estimate: 45%; middle value at least 1.2-fold (0.07 log units) from the limit.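

In this assay, methyl in place of phenyl on this carbon, which turns benzyloxy into ethoxy, gives an at least 2.1-fold higher number from compound 2 to compound 3 (0.33 log units; beyond the scatter), so the effect of the phenyl now shows from both sides, on its arrival and on its removal. Compound 3 gives > 300000 nM, which is a limit of the assay and not a number. The step between the methoxy compound 1 and the ethoxy compound 3 cannot be read, so the added methyl shows no readable effect here, and among these three groups only benzyloxy gives an actual number: the limit of > 300000 nM in this assay, at which 2 of the 3 values shown sit.

As far as these compounds go, how far compound 1 and compound 3 lie beyond that limit stays open, and with it the full size of what the phenyl adds. Also open, from the compounds shown here alone, is whether a longer chain, an amine or a carboxylic acid on this same carbon would give a number too, or whether the six-membered aromatic ring of the phenyl is needed for one.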